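Phenoxymethyl-pyrazolo-lactam series: para-methoxy analogue of compound 3

The source may hold more compounds than are shown below. What is called first, only, known or untested is meant among the compounds shown, and "the series" means these compounds.

Measured compounds and values:
compound 1, `O=C1c2cc(COc3ccccc3)nn2CCN1c1cccc(F)c1`, 81%
compound 2, `O=C1c2cc(COc3ccccc3)nn2CCN1c1ccc(F)c(F)c1`, 81%
compound 3, `Cc1ccc(N2CCn3nc(COc4ccccc4)cc3C2=O)cc1`, 65%

All values come from a functional assay on HEK293 cells for positive allosteric modulation of metabotropic glutamate receptor 5 (Homo sapiens), read by calcium flux; on this read-out higher numbers stand for larger maximal responses and lower numbers for smaller maximal responses. Compound 1 and compound 2 share one value, and the step of no change at the digits printed from compound 1 to compound 2 (within the scatter) is within the scatter. Compound 3 stands lowest of the three numbers; the gap to its nearest neighbour is a number 16 percentage points lower from compound 1 to compound 3 (beyond the scatter), and to the furthest it is a number 16 percentage points lower from compound 2 to compound 3 (beyond the scatter), both beyond the scatter and both arising from an exchange of the whole ring on the amide-type nitrogen.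

Compound 4, `COc1ccc(N2CCn3nc(COc4ccccc4)cc3C2=O)cc1`, is not yet measured in this assay. Relative to compound 3 the change is methoxy in place of methyl on an aromatic carbon.

Among the compounds with values here, none of the measured steps bears directly on this change: the step from compound 1 to compound 2 is a fluoro for hydrogen exchange on the same kind of ring, and the two steps leading to compound 3 replace the ring as a whole, not a single group para to a large group. Within the data shown here, a methyl to methoxy exchange at this site has no precedent, so no step beyond the scatter is expected.

Compound 4 is therefore estimated at 65% in this assay, with a range of 50% to 80%, meaning an expected step of no change at the digits printed from compound 3 to compound 4 (within the scatter).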

Compound 4, largest response reached (Emax), in percent of the reference or control that the assay uses: 58%
Beside the measured number, compound 4's estimate is 7 percentage points above it, within the range that was stated.
By their numbers in this assay, from the lowest: compounds 4 and 3 (each within the scatter of the next); then compounds 1 and 2 (each within the scatter of the next).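

In this assay, methoxy in place of methyl on an aromatic carbon para to a large group gives the first single-group exchange read at this place (a number 7 percentage points lower from compound 3 to compound 4 (within the scatter)), and it does not separate the 4-methoxyphenyl compound from the 4-methylphenyl compound. The gap to the fluorinated rings therefore holds for a second group at this place (a number 23 percentage points lower from compound 1 to compound 4 (beyond the scatter); a number 23 percentage points lower from compound 2 to compound 4 (beyond the scatter)), although each of these steps exchanges the whole ring and cannot be assigned to one substituent. Nothing measured for these compounds accounts for the separation between the two sets of rings.

Within the data shown here, still open is whether the gap follows the fluoro groups or the group at this place, as no pair here differs in only that respect. Also open, as far as these compounds go, is how this place responds to groups of another kind, such as an amine, a carboxylic acid or a longer chain like ethoxy, so the reading for methyl and methoxy cannot yet be extended to a wider set.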